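A few compounds are considered here, and "the series" means these few. Any claim that something is new, unique, unknown or untested is made for them only; others in the source may bear on it.

Measured so far in a toxicity assay on HEK-293T cells (Homo sapiens) for cytotoxicity, read by CCK-8 assay, with a stated time of 48 h; a lower number here means that less compound is tolerated, a higher number that more compound is tolerated:
compound 1 `Cn1cc(SCc2nnc(SCc3ccccc3C#N)n2-c2c(Cl)cccc2Cl)c2ccccc21` gives 78600 nM
compound 2 `Cn1cc(SCc2nnc(SCc3cc(C(F)(F)F)ccc3Cl)n2-c2c(Cl)cccc2Cl)c2ccccc21` gives 53800 nM
compound 3 `Cn1cc(SCc2nnc(SCc3c(Cl)cccc3Cl)n2-c2c(Cl)cccc2Cl)c2ccccc21` gives only a limit of the assay, > 100000 nM

Compound 1 and compound 2 lie within the scatter of each other in this assay: a 1.5-fold lower number from compound 1 to compound 2 (0.16 log units; within the scatter). The third value is a limit, (the limit of > 100000 nM in this assay, at which 1 of the 3 values shown sits). The step of an at least 1.2-fold higher number from compound 1 to compound 3 (0.10 log units; that floor lies within the scatter) is therefore only a floor. The step of an at least 1.8-fold higher number from compound 2 to compound 3 (0.26 log units; that floor lies within the scatter) is likewise only a floor.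

Compound 4 `Cn1cc(SCc2nnc(SCc3ccc(Cl)c(F)c3)n2-c2c(Cl)cccc2Cl)c2ccccc21` differs from compound 1 in one place: 4-chloro-3-fluorophenyl in place of 2-cyanophenyl on a saturated chain carbon bound to a sulfur. Both measured steps away from compound 1 replace the 2-cyanophenyl with a chlorinated phenyl on the same saturated chain carbon bound to a sulfur, and neither moves beyond the scatter; the 2,6-dichlorophenyl analogue reaches the limit. Nothing among these three compounds sets a 4-chloro-3-fluorophenyl apart from those groups, so no step beyond the scatter is expected for compound 4: a 1.1-fold higher number from compound 1 to compound 4 (0.03 log units; within the scatter). Compound 4 is estimated at 85000 nM, with a range from 40000 nM to 180000 nM, and a fair chance that only a limit is reported.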

Compound 4, half-maximal cytotoxic concentration: > 100000 nM
Compound 4: no number, only a limit (the forecaster's own chance of this, stated with the estimate: 35%); middle value at least 1.1-fold (0.07 log units) from the limit.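

In this assay compound 4 gives only a limit, > 100000 nM. Both readable steps are floors within the scatter, an at least 1.2-fold higher number from compound 1 to compound 4 (0.10 log units; that floor lies within the scatter) and an at least 1.8-fold higher number from compound 2 to compound 4 (0.26 log units; that floor lies within the scatter), so the 4-chloro-3-fluorophenyl cannot be told apart from the 2-cyanophenyl or the 2-chloro-5-(trifluoromethyl)phenyl on this saturated chain carbon bound to a sulfur. A second group at this position now reaches the limit alongside the 2,6-dichlorophenyl of compound 3, the step between those two compounds cannot be read, and the series increasingly runs into the top of the assay: the limit of > 100000 nM in this assay, at which 2 of the 4 values shown sit.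

As far as these compounds go, how far compound 3 and compound 4 extend past the limit stays unknown, so these groups cannot be ranked. Also open, from the compounds shown here alone, is whether a phenyl carrying an amine or a carboxylic acid on the same carbon would give a step beyond the scatter.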